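Aryl Swap on the Hydrazide Carbonyl: Chlorophenyl to Aminophenyl

The compounds below may be only part of what the source reports. "The series", "measured", "known", "first", "only" and "open" are said of these compounds alone.

Compound 1 `Cc1ccc(C(=O)N/N=C/C2=C(Cl)c3ccccc3CCC2)cc1`: 710 nM
Compound 2 `O=C(N/N=C/C1=C(Cl)c2ccccc2CCC1)c1cccc(Cl)c1`: 16300 nM

In a functional assay on MDA-MB-231 cells (Homo sapiens) for inhibition, read by sulforhodamine B assay, with a stated time of 48 h (a lower number here means a stronger inhibitor of growth, a higher number a weaker inhibitor of growth), compound 2 gives 16300 nM, the highest of the two numbers; its nearest neighbour, compound 1, gives 710 nM. Compound 3 `Nc1ccccc1C(=O)N/N=C/C1=C(Cl)c2ccccc2CCC1` carries 2-aminophenyl in place of 3-chlorophenyl on a carbonyl carbon. For the measured compounds named here, one measured step bears on this position: a 23-fold higher number from compound 1 to compound 2 (1.36 log units; beyond the scatter), showing that exchanging the aryl group on the carbonyl carbon can move the number a great deal. Going by the values given here, no measured compound carries the 2-aminophenyl, so the direction cannot be read from the data. Compound 3 is therefore expected to give 5000 nM, estimated between 800 nM and 30000 nM. This expectation amounts to a 3.3-fold lower number from compound 2 to compound 3 (0.51 log units; beyond the scatter).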

Compound 3, concentration for 50% growth inhibition: 5000 nM
For compound 3 middle estimate and measured number coincide at the digits printed; the range from low to high includes it.
By their numbers in this assay, from the lowest: compound 1; then compound 3; then compound 2.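

In this assay the 2-aminophenyl on the carbonyl carbon gives a 3.3-fold lower number from compound 2 to compound 3 (0.51 log units; beyond the scatter) and also a 7.0-fold higher number from compound 1 to compound 3 (0.85 log units; beyond the scatter) in the same assay. A third aryl group thus falls in the middle of the two earlier ones: an amine-bearing ring improves on the 3-chlorophenyl but does not match the 4-methylphenyl. No measurement at hand explains this order. The compounds shown leave open whether the amine itself matters, and how an unsubstituted phenyl, or a ring carrying a hydroxyl or methoxy group instead of the amine, would compare.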